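Trifluoromethyl for fluoro on the aryl piperazine

The source may report more compounds than this note shows. Statements on the series, on what has been measured and on what is new or still open speak of the compounds shown alone.

Measured so far:
compound 1 `CCC(C(=O)N1CCN(c2cccc(Cl)c2)CC1)N1C(=O)CCC1=O` gives 25%
compound 2 `COCC(C(=O)N1CCN(c2cccc(C(F)(F)F)c2)CC1)N1C(=O)CCC1=O` gives 100%
compound 3 `CCC(C(=O)N1CCN(c2cccc(F)c2)CC1)N1C(=O)CCC1=O` gives 0%

The read-out throughout is a functional assay on the whole organism (strain Swiss) with Mus musculus as the target, in the maximal electroshock model, with a stated time of 2 h, at a dose of 300 mg/kg by the intraperitoneal route; on this read-out lower numbers stand for a weaker effect and higher numbers for a stronger effect at the one dose given. Among the three measured compounds, compound 3 stands lowest. Its nearest neighbour is compound 1, from which it differs only by fluoro in place of chloro on an aromatic carbon; that step, a number 25 percentage points lower from compound 1 to compound 3 (beyond the scatter), is modest but beyond the scatter. Furthest away is compound 2, which reaches the top of the scale, but compound 2 differs from compound 3 in two places, so no single step connects them.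

Compound 4 `CCC(C(=O)N1CCN(c2cccc(C(F)(F)F)c2)CC1)N1C(=O)CCC1=O` is not yet measured. It differs from compound 3 as follows: trifluoromethyl in place of fluoro on an aromatic carbon. Among the compounds with values here, only one measured step bears directly on this change: the loss from compound 1 to compound 3 when the smaller halogen replaced the larger one. Reversing that direction with a group of four heavy atoms, and noting that the only measured compound carrying trifluoromethyl, compound 2, gives 100%, one expects a rise for compound 4, with a wide margin since compound 2 also carries a different chain. The step is estimated as a number 50 percentage points higher from compound 3 to compound 4 (beyond the scatter). Compound 4 is therefore expected to give 50%, in the range 10% to 100%.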

Compound 4, a percentage reported as activity, at one dose (the size of the read-out at that dose, not a potency): 50%
For compound 4 middle estimate and measured number coincide at the digits printed, within the range that was stated.
By their numbers in this assay, from the lowest: compound 3; then compound 1; then compound 4; then compound 2.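

In this assay, trifluoromethyl in place of fluoro on the aromatic carbon gives a number 50 percentage points higher from compound 3 to compound 4 (beyond the scatter), and trifluoromethyl in place of chloro gives a number 25 percentage points higher from compound 1 to compound 4 (beyond the scatter). Within the data shown here, the earlier compounds offered only one step at this position, whereas these compounds, which share the same chain, now rank fluoro, chloro and trifluoromethyl in that rising order, with every step beyond the scatter. Among these compounds, compound 4 also gives the first reading on the chain: methyl in place of methoxy on a saturated chain carbon, two bonds along the chain from an amide-type nitrogen in a ring and a carbonyl carbon, gives a number 50 percentage points lower from compound 2 to compound 4 (beyond the scatter), so trifluoromethyl alone does not reach the top reading of compound 2. Nothing at hand explains why these steps run as they do.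

From the compounds shown here alone, whether methoxy on the chain would also raise the readings of the chloro and fluoro compounds remains open. Also open, going by these compounds, is how a nitrile on the aromatic carbon, or a longer chain in place of the methyl, would fare in this assay.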